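Swapping Ethyl for Dimethoxyphenyl on the Ring Nitrogen

The source may hold more compounds than are shown below. What is called first, only, known or untested is meant among the compounds shown, and "the series" means these compounds.

Of the compounds shown here, three sharing a five-membered ring core have been measured so far in a functional assay on U2OS cells (Homo sapiens) for inhibition, read by CCK-8 assay, with a stated time of 72 h, tested at 1 uM; on this read-out lower numbers stand for less inhibition and higher numbers for more inhibition at the one concentration tested (going by the name of the read-out). Compound 1 `COc1ccccc1N1C(=O)CSC1c1cc(F)cc(C(=O)O)c1` gives 15% in this assay. Compound 2 `CCN1C(=O)CSC1c1cccc(C(=O)NCCCCc2ccccc2)c1` gives 13%, and compound 3 `COc1ccccc1N1C(=O)CSC1C(=O)NCCCCc1ccccc1` gives 6%. Compound 2 has the second highest of these three numbers; its nearest neighbour is compound 1, and the gap between them is within the usual scatter of repeated measurements, while its furthest neighbour is compound 3, and that gap too is within the scatter. All three numbers therefore describe weak inhibition at the single concentration tested, and none can be called stronger or weaker than another.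

Compound 4 `COc1ccc(N2C(=O)CSC2c2cccc(C(=O)NCCCCc3ccccc3)c2)c(OC)c1` has not been measured. It differs from compound 2 in one place: 2,4-dimethoxyphenyl in place of ethyl on an amide-type nitrogen in a ring. Among the measured compounds shown here, no pair of measured compounds differs by exactly this change, so there is no measured step to lean on. For compound 4 the expected step of a number 1 percentage points higher from compound 2 to compound 4 (within the scatter) in this assay is small, no larger than the scatter, with no clear direction. Compound 4 is thus estimated at 14%, with a range from 0% to 35%.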

Compound 4, a percentage reported as inhibition, at one concentration (the size of the read-out at that concentration, not a potency): 37%
Compound 4: the middle estimate sits 23 percentage points below what was measured, outside the stated range (above it).
By their numbers in this assay, from the lowest: compounds 3, 2 and 1 (each within the scatter of the next); then compound 4.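

The ring nitrogen is not a silent position: in this assay, putting 2,4-dimethoxyphenyl in place of ethyl on this amide-type nitrogen in a ring gives a step of a number 24 percentage points higher from compound 2 to compound 4 (beyond the scatter) that lies beyond the usual scatter. The earlier compounds shown here could not show this, as no two of them differ in only one place. The change replaces 2 heavy atoms and no ring with 10 heavy atoms, one six-membered aromatic ring and 2 hydrogen-bond acceptors, and no measurement here explains why the number rises.

The ring and both methoxy groups enter together. The step cannot be credited to any one of them, and an unsubstituted phenyl or a phenyl with a single methoxy group on the same nitrogen would help to separate their contributions. On these data alone, a longer alkyl chain such as butyl would test whether extra carbon atoms alone go with a similar rise, and since each number comes from one concentration, the potency of compound 4 also remains open.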